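Swapping Thiophene for Methylpyrazole in Compound 1

The source may report more compounds than this note shows. Statements on the series, on what has been measured and on what is new or still open speak of the compounds shown alone.

Compound 1 `O=C(/C=C/c1ccsc1)c1cc(O)c(O)c([N+](=O)[O-])c1` gives the highest of the three numbers in an assay for inhibition of Catechol O-methyltransferase (Rattus norvegicus), read by fluorescence and spectrophotometry (on this read-out lower numbers stand for stronger inhibition and higher numbers for weaker inhibition), at 230 nM. Compound 2 `CC(=O)N1N=C(c2cc(O)c(O)c([N+](=O)[O-])c2)CC1c1ccco1` gives 180 nM and compound 3 `CC(=O)N1N=C(c2cc(O)c(O)c([N+](=O)[O-])c2)CC1c1nccs1` gives 160 nM; both gaps from compound 1 lie within the scatter, so no order among the three can be claimed. For the measured compounds named here, the only measured step, a 1.1-fold lower number from compound 2 to compound 3 (0.05 log units; within the scatter), exchanges one five-membered aromatic ring for another and stays within the scatter. Compound 4 `Cn1cc(/C=C/C(=O)c2cc(O)c(O)c([N+](=O)[O-])c2)cn1` differs from compound 1 in one place: 1-methyl-1H-pyrazol-4-yl in place of thiophen-3-yl on a double-bonded chain carbon bound to a double-bonded chain carbon. This is again an exchange of one five-membered aromatic ring for another, on a chain carbon rather than a ring carbon, so no step beyond the scatter is expected in this assay. Compound 4 is therefore estimated at 250 nM, with a range from 80 nM to 800 nM. The expected step of a 1.1-fold higher number from compound 1 to compound 4 (0.04 log units; within the scatter) is taken to lie within the scatter.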

Compound 4, half-maximal inhibitory concentration: 290 nM
Beside the measured number, compound 4's estimate is 1.2-fold (0.06 log units) below it, within the range that was stated.
By their numbers in this assay, from the lowest: compounds 3, 2, 1 and 4 (each within the scatter of the next).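

On a double-bonded chain carbon bound to a double-bonded chain carbon, 1-methyl-1H-pyrazol-4-yl in place of thiophen-3-yl gives a 1.3-fold higher number from compound 1 to compound 4 (0.10 log units; within the scatter) in this assay. Where the earlier step exchanged five-membered aromatic rings on a saturated ring carbon, this one shows the same kind of exchange staying within the scatter at this chain position, even with 2 hetero atoms entering for 1. No measurement at hand offers an explanation for this result. The compounds shown leave open whether an amine or a carboxylic acid in place of the ring at this position would move the number beyond the scatter.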